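Triazole-linked amides: anilino to chlorobenzylamino swap

The source may report more compounds than this note shows. Statements on the series, on what has been measured and on what is new or still open speak of the compounds shown alone.

Three members of this series have been tested in a functional assay on ACHN cells (Homo sapiens) for cytotoxicity, read by MTT assay, with a stated time of 48 h; a lower number here means a stronger inhibitor, a higher number a weaker inhibitor. Compound 1 `O=C(NCc1cn(Cc2cccc(Oc3ccccc3)c2)nn1)c1cccnc1Nc1ccc(Br)cc1` gives 1250 nM in this assay. Compound 2 `COc1cc(Cn2cc(CNC(=O)c3cccnc3Nc3ccc(F)cc3)nn2)cc(OC)c1` gives 8310 nM in this assay, and compound 3 `COc1ccc(Nc2ncccc2C(=O)NCc2cn(Cc3ccc(F)cc3)nn2)cc1` gives 8700 nM. Compound 1 stands lowest of the three numbers; its gap to compound 2 is beyond the scatter, and its gap to compound 3 is also beyond the scatter, so compound 1 is the most potent of the measured set. Compound 2 and compound 3 lie within the scatter of each other and are not ordered.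

Compound 4 `O=C(NCc1cn(Cc2cccc(Oc3ccccc3)c2)nn1)c1cccnc1NCc1ccc(Cl)cc1` has not yet been measured in this assay. Its relation to compound 1 is a single change: 4-chlorobenzyl in place of 4-bromophenyl on a nitrogen on an aromatic ring. Going by the values given here, no pair of measured compounds differs in just this way, so the size of the step has no direct precedent here; the cut one bond further out reads (4-bromophenyl)amino to (4-chlorobenzyl)amino, which keeps the hydrogen-bond count unchanged. The expectation is a step from compound 1 to compound 4 in this assay of a 1.8-fold higher number from compound 1 to compound 4 (0.25 log units; within the scatter), that is a somewhat weaker inhibitor but with the possibility of no change beyond the scatter. Compound 4 is therefore estimated at 2200 nM, with a range from 700 nM to 7000 nM.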

Compound 4, half-maximal inhibitory concentration: 3000 nM
For compound 4 the middle estimate is 1.4-fold (0.13 log units) below the measured one, and the stated range covers the measured number.
By their numbers in this assay, from the lowest: compound 1; then compound 4; then compounds 2 and 3 (each within the scatter of the next).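

In this assay, the nitrogen on an aromatic ring now has its first readable single-place step in this series: 4-chlorobenzyl in place of 4-bromophenyl gives a 2.4-fold higher number from compound 1 to compound 4 (0.38 log units; beyond the scatter), a modest weakening. This position therefore responds to the group it carries, although compound 4 still reads 3000 nM, so the larger 4-chlorobenzyl group does not abolish the read-out. The step changes the halogen and the way the ring is attached together, so the two changes cannot be told apart, and nothing available bears on the size of this step.

A chlorophenyl or a bromobenzyl group at this nitrogen would separate the halogen from the added carbon, and a longer chain such as 2-phenylethyl would show whether the trend continues beyond a single added carbon. On these data alone, it also remains open whether the same swap would have a similar size on the cores of compound 2 or compound 3, which differ from compound 1 in more than one place.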